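The source may hold more compounds than are shown below. What is called first, only, known or untested is meant among the compounds shown, and "the series" means these compounds.

In a functional assay on PC-3 cells (Homo sapiens) for antiproliferative activity, read by sulforhodamine B assay, with a stated time of 48 h, tested at 50 uM (on this read-out higher numbers stand for more inhibition at the one concentration tested (going by the name of the read-out) and lower numbers for less inhibition), compound 2 `CC1=CC[C@H](C(C)C)c2cc(C)c(OC(=O)c3cccc(C(F)(F)F)c3)cc21` gives 25.4%, the upper one of the two numbers in hand, though its gap to compound 1 is within the scatter. Compound 1 `CC1=CC[C@H](C(C)C)c2cc(C)c(OC(=O)c3cccc(Cl)c3)cc21` gives 23.4% in this assay, and the step is a number 2 percentage points higher from compound 1 to compound 2 (within the scatter). Compound 3 `CC1=CC[C@H](C(C)C)c2cc(C)c(OC(=O)c3cccc(C)c3)cc21` differs from compound 2 by methyl in place of trifluoromethyl on an aromatic carbon. Among the measured compounds shown here, the only measured step, chloro to trifluoromethyl at the same place, stayed within the scatter, so no shift beyond it is expected here; the estimated step is a number 0.4 percentage points lower from compound 2 to compound 3 (within the scatter). Compound 3 is therefore expected to show 25%, between 12% and 38%.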

Compound 3, a percentage reported as inhibition, at one concentration (the size of the read-out at that concentration, not a potency): 38.6%
The estimate for compound 3 lay 13.6 percentage points below the measured number; measured number above the stated range.
By their numbers in this assay, from the lowest: compounds 1 and 2 (each within the scatter of the next); then compound 3.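

In this assay, this place, meta to a large group, proves able to move the number: methyl in place of trifluoromethyl gives a number 13.2 percentage points higher from compound 2 to compound 3 (beyond the scatter) and methyl in place of chloro gives a number 15.2 percentage points higher from compound 1 to compound 3 (beyond the scatter), whereas the exchange of chloro for trifluoromethyl had stayed within the scatter. Of the three groups, methyl alone stands apart from the other two. Nothing available accounts for this difference.

The compounds shown leave open whether an ethyl group, a longer chain, a methoxy group or an amine at this place would raise the number further or lower it.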